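The source may report more compounds than this note shows. Statements on the series, on what has been measured and on what is new or still open speak of the compounds shown alone.

Measured so far in a physicochemical assay for lipophilicity, using the shake flask method, measured as octanol-water partition, with a stated time of 30 min, at pH 7.4; a lower number here means a more polar compound, a higher number a more lipophilic compound:
- compound 1 `COc1ccc(-n2cc3nc(-c4cccnc4C)n(C[C@H]4CCCN(C[C@H]5CCCO5)C4)c(=O)c3n2)cc1` gives 1.9
- compound 2 `Cc1ccccc1-c1nc2cn(-c3cccc(C#N)c3)nc2c(=O)n1CC1CCCN(C(C)C)C1` gives 1.8

Compound 1 and compound 2 lie within the scatter of each other, so the two numbers do not separate them. Compound 3 `Cc1ncccc1-c1nc2cn(-c3cccc(OC(C)C)c3)nc2c(=O)n1C[C@H]1CCCN(C[C@H]2CCCO2)C1` differs from compound 1 in one place, 3-isopropoxyphenyl in place of 4-methoxyphenyl on an aromatic nitrogen, with 3-isopropoxyphenyl in place of 4-methoxyphenyl on an aromatic nitrogen as the full difference. Among the compounds with values here, no measured pair gives the size of such a change, and the expectation rests on the structural change alone. In this assay a moderate upward step beyond the scatter is expected, estimated as a number 0.60 log units higher from compound 1 to compound 3 (beyond the scatter) in size. For compound 3 the estimated value is 2.5 with an expected range from 2.1 to 2.9 for this measurement.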

Compound 3, distribution coefficient: 2.7
Compound 3: middle estimate off by 0.20 log units, on the low side, within the range that was stated.
By their numbers in this assay, from the lowest: compounds 2 and 1 (each within the scatter of the next); then compound 3.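

In this assay, within the data shown here, 3-isopropoxyphenyl in place of 4-methoxyphenyl on the aromatic nitrogen gives a number 0.80 log units higher from compound 1 to compound 3 (beyond the scatter) and provides the first measured step at this position. The number therefore moves with this substituent while the rest of compound 1 stays fixed. No available data bear on the origin of this step.

As far as these compounds go, it remains open how the step divides between isopropoxy against methoxy and the change of substituent place on the phenyl ring. 3-Methoxyphenyl or 4-isopropoxyphenyl on the same nitrogen would separate the two.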